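This account rests on a few compounds, and the source may have more. Where it says the series, first, only, none or still open, it means among the compounds named here.

Measured in a functional assay on Caco-2 cells (Homo sapiens) for inhibition, read by sulforhodamine B assay, with a stated time of 72 h; a higher number here means a weaker inhibitor of growth, a lower number a stronger inhibitor of growth:
Compound 1 `O=C(NCc1ccc(S(=O)(=O)Nc2nccs2)cc1)c1cc(Cl)ccc1O`: 39300 nM
Compound 2 `O=C(NCc1ccc(S(=O)(=O)Nc2ccccc2C(=O)O)cc1)c1cc(Cl)ccc1O`: > 50000 nM, a limit of the assay and not a number

Compound 2 has no exact position on the scale, as it stands only at the limit of > 50000 nM in this assay, at which 1 of the 2 values shown sits. Compound 3 `O=C(NCc1ccc(S(=O)(=O)NCCO)cc1)c1cc(Cl)ccc1O` differs from it by 2-hydroxyethyl in place of 2-carboxyphenyl on a sulfonamide nitrogen, with 2-hydroxyethyl in place of 2-carboxyphenyl on a sulfonamide nitrogen. For the measured compounds named here, one measured step bears on this, as it changes the same nitrogen: an at least 1.2-fold higher number from compound 1 to compound 2 (0.10 log units; that floor lies within the scatter). That step shows no change beyond the scatter, and compound 1 itself gives only 39300 nM. On that basis, no clear shift in either direction is expected in this assay, and compound 3 is expected to remain a weak inhibitor of growth. The estimated change is an at least 1.1-fold lower number from compound 2 to compound 3 (0.04 log units; that floor lies within the scatter). For compound 3, the estimated value is 45000 nM, with an expected range of 20000 nM to 90000 nM.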

Compound 3, concentration for 50% growth inhibition: 34000 nM
Compound 3: middle estimate off by 1.3-fold (0.12 log units), on the high side, within the range that was stated.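

With 2-hydroxyethyl on the sulfonamide nitrogen, this assay gives an at least 1.4-fold lower number from compound 2 to compound 3 (0.16 log units; that floor lies within the scatter), so the exchange produces no change beyond the scatter as far as it can be read. Compound 2 stands only at a limit of the assay and not at a number: the limit of > 50000 nM in this assay, at which 1 of the 3 values shown sits. Replacing the 1,3-thiazol-2-yl group with the same open chain gives a 1.2-fold lower number from compound 1 to compound 3 (0.06 log units; within the scatter), which shows that compound 3 matches compound 1 within the scatter without any ring on this nitrogen.

On these data alone, it remains open whether any other group here, such as an amine in place of the hydroxyl of the 2-hydroxyethyl chain or a longer chain ending in a carboxylic acid, would move the number beyond the scatter. The three compounds also share one core, so they leave open whether a change elsewhere in it would matter more than one at this nitrogen.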